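Taking One Methyl Away from Compound 1

This account rests on a few compounds, and the source may have more. Where it says the series, first, only, none or still open, it means among the compounds named here.

In a functional assay on HeLa cells (Homo sapiens) for inhibition (on this read-out lower numbers stand for stronger inhibition and higher numbers for weaker inhibition), compound 1 `Cc1ccc(C(=O)CC(SCC(=O)O)C(=O)O)cc1C` gives 3810 nM, compound 2 `Cc1ccc(C(=O)CC(SCC(=O)O)C(=O)O)c(C)c1` gives 3830 nM and compound 3 `Cc1ccc(C)c(C(=O)CC(SCC(=O)O)C(=O)O)c1` gives 2680 nM. Compound 1 therefore stands level with the other two, all three values lying within the scatter of one another. Compound 4 `Cc1ccc(C(=O)CC(SCC(=O)O)C(=O)O)cc1` carries hydrogen in place of methyl on an aromatic carbon. Among the measured compounds shown here, no measured pair shows this change directly. The placing of the methyl groups differs among compound 1, compound 2 and compound 3 without any step beyond the scatter, so little movement is expected in this assay, if anything toward a slightly higher number. The estimated step is a 1.2-fold higher number from compound 1 to compound 4 (0.07 log units; within the scatter), which is expected to stay within the scatter. For compound 4 the expected value is 4500 nM, with an estimated range from 2200 nM to 9000 nM.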

Compound 4, half-maximal inhibitory concentration: 17300 nM
Beside the measured number, compound 4's estimate is 3.8-fold (0.58 log units) below it, outside the stated range (above it).
By their numbers in this assay, from the lowest: compounds 3, 1 and 2 (each within the scatter of the next); then compound 4.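

In this assay, hydrogen in place of methyl on an aromatic carbon, ortho to a methyl group and meta to a large group, brings a 4.5-fold higher number from compound 1 to compound 4 (0.66 log units; beyond the scatter), a step beyond the scatter. The same change gives a 4.5-fold higher number from compound 2 to compound 4 (0.65 log units; beyond the scatter), so a ring methyl that seemed unimportant while the methyl groups only changed places does matter once one is taken away. No measurement given here accounts for this step.

The compounds shown leave open whether a chlorine or a methoxy group on that carbon would do what methyl does. They also leave open how an ethyl group there would compare.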